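Working notes: from compound 2 to compound 3

This account rests on a few compounds, and the source may have more. Where it says the series, first, only, none or still open, it means among the compounds named here.

Measured so far:
compound 1 `O=CN(O)[C@@H](CCCc1ncccn1)CS(=O)(=O)N1CCN(c2ccc(Cl)cn2)CC1` — < 10000 nM
compound 2 `O=CN(O)C(CCCc1ncccn1)CS(=O)(=O)N1CCC(Oc2ccc(Cl)cn2)CC1` — < 10000 nM

In an ADME assay for inhibition of Bile salt export pump (Homo sapiens), read by scintillation counting, with a stated time of 5 min (on this read-out lower numbers stand for stronger inhibition and higher numbers for weaker inhibition), compound 1 gives < 10000 nM, which is a limit of the assay and not a number. In this assay compound 2 gives < 10000 nM, again a limit rather than a number. Among the compounds with values here, compound 2 therefore stands exactly where every value shown stands, at the limit of < 10000 nM in this assay, at which 2 of the 2 values shown sit; no step between measured compounds can be worked out, and nothing separates compound 1 from compound 2 on the numbers available.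

Compound 3 `O=CN(O)C(CCc1cccnc1)CS(=O)(=O)N1CCC(Oc2ccc(Cl)cn2)CC1` is still to be measured in this assay. Against compound 2 the change is pyridin-3-yl in place of (pyrimidin-2-yl)methyl on a saturated chain carbon, three bonds along the chain from an amide-type nitrogen. Within the data shown here, with no measured step anywhere and both values being limits, there is nothing to anchor the direction or size of the move from compound 2 to compound 3; the expectation is none beyond the scatter of this assay. The estimate implies the step that the limit leaves unreadable from compound 2 to compound 3 in this assay. Compound 3 is expected to give about 5000 nM, with a range from 1000 nM to 25000 nM, and a limit rather than a number is the more likely report.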

Compound 3, half-maximal inhibitory concentration: < 10000 nM
Compound 3 ended at the assay's limit; the forecaster's own chance of this, stated with the estimate: 65%; the middle value does not contradict the limit.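

In this assay compound 3 gives < 10000 nM which is a limit of the assay and not a number. No step can be read from compound 2 to compound 3, since both report only a limit: the limit of < 10000 nM in this assay, at which 3 of the 3 values shown sit.

From the compounds shown here alone, whether compound 1, compound 2 and compound 3 differ at all in this read-out remains open, as does the effect of pyridin-3-yl in place of (pyrimidin-2-yl)methyl.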